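Benzyl substituent variation in a tetrafluorophenoxymethyl ketone series

A few compounds are considered here, and "the series" means these few. Any claim that something is new, unique, unknown or untested is made for them only; others in the source may bear on it.

In a functional assay on Jurkat cells (Homo sapiens) (on this read-out lower numbers stand for stronger inhibition and higher numbers for weaker inhibition), compound 2 `C[C@H](NC(=O)C(=O)NCc1cccc(F)c1)C(=O)N[C@@H](CC(=O)O)C(=O)COc1c(F)c(F)cc(F)c1F` gives 106 nM. Compound 1 `Cc1cccc(CNC(=O)C(=O)N[C@@H](C)C(=O)N[C@@H](CC(=O)O)C(=O)COc2c(F)c(F)cc(F)c2F)c1` gives 127 nM in this assay, and the two numbers lie within the scatter of each other, so neither stands apart. Going by the values given here, the only step between measured compounds, a 1.2-fold lower number from compound 1 to compound 2 (0.08 log units; within the scatter), is a fluoro in place of methyl on an aromatic carbon and did not move the read-out beyond the scatter. Compound 3 `C[C@H](NC(=O)C(=O)NCc1cccc(Cl)c1Cl)C(=O)N[C@@H](CC(=O)O)C(=O)COc1c(F)c(F)cc(F)c1F` differs from compound 2 by 2,3-dichlorophenyl in place of 3-fluorophenyl on a saturated chain carbon bound to an amide-type nitrogen. Among the compounds with values here, no measured step covers a dichloro substitution; the one available step, a 1.2-fold lower number from compound 1 to compound 2 (0.08 log units; within the scatter), shows that a small change at this ring left the number essentially unchanged. On that basis compound 3 is expected to stay close to compound 2, with an estimated step of a 1.1-fold lower number from compound 2 to compound 3 (0.03 log units; within the scatter). The estimate for compound 3 in this assay is 100 nM, with an expected range from 40 nM to 250 nM, kept wide given the absence of any measured precedent for this change.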

Compound 3, half-maximal inhibitory concentration: 76 nM
Estimate against measurement, compound 3: 1.3-fold (0.12 log units) above; low and high end bracket the measured number.
By their numbers in this assay, from the lowest: compounds 3, 2 and 1 (each within the scatter of the next).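

On the shared core, 2,3-dichlorophenyl in place of 3-fluorophenyl on the saturated chain carbon bound to an amide-type nitrogen gives a 1.4-fold lower number from compound 2 to compound 3 (0.14 log units; within the scatter) in this assay, and the same group in place of 3-methylphenyl gives a 1.7-fold lower number from compound 1 to compound 3 (0.22 log units; within the scatter). This position therefore accepts two chlorine atoms on the ring, with 8 heavy atoms in the group against 7 for 3-fluorophenyl, and the number stays within the scatter for all three compounds. Nothing measured here accounts for this result.

The compounds shown leave open whether a carboxylic acid or an amine on this ring, or a longer chain between the ring and the amide-type nitrogen, would move the number beyond the scatter. On these data alone, all three share one core, so the behaviour of 2,3-dichlorobenzyl on any other core also remains open.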